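Chloro in place of hydrogen: compound 4 against compound 1

A few compounds are considered here, and "the series" means these few. Any claim that something is new, unique, unknown or untested is made for them only; others in the source may bear on it.

Measured so far:
compound 1 `CC(C)c1onc(-c2c(Cl)cccc2Cl)c1COc1ccc(-c2nc3ccc(C(=O)O)cc3n2C)cc1` — 7150 nM
compound 2 `CC(C)c1onc(-c2c(Cl)cccc2Cl)c1COc1ccc(-c2nc3ccc(C(=O)O)cc3n2CC(C)(C)C)cc1` — 861 nM
compound 3 `CC(C)c1onc(-c2c(Cl)cccc2Cl)c1COc1ccc(-c2nc3ccc(C(=O)O)cc3n2C2CC2)cc1` — 3200 nM

All three numbers come from an assay on HEK-293T cells for antagonist activity at vitamin D3 receptor (Homo sapiens), read by a luciferase reporter, with a stated time of 24 h; a lower number here means a stronger inhibitor, a higher number a weaker inhibitor. Compound 1 stands at the highest number of the three: the step to compound 3 is a 2.2-fold lower number from compound 1 to compound 3 (0.35 log units; beyond the scatter), the step to compound 2 is an 8.3-fold lower number from compound 1 to compound 2 (0.92 log units; beyond the scatter), and between the two substituted analogues the step is a 3.7-fold higher number from compound 2 to compound 3 (0.57 log units; beyond the scatter). Every one of these steps changes only the group on the aromatic nitrogen of the shared core.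

Compound 4 `CC(C)c1onc(-c2c(Cl)cccc2Cl)c1COc1ccc(-c2nc3ccc(C(=O)O)cc3n2C)c(Cl)c1` differs from compound 1 in a different place: chloro in place of hydrogen on an aromatic carbon. The chloro enters on an aromatic carbon of a six-membered aromatic ring of carbon only, ortho to a large group and meta to a large group. Among the compounds with values here, no measured step touches that ring, so none of them bears on the change, and nothing here sets a direction for it. Compound 4 is therefore expected to stay close to compound 1, an estimated step of a 1.1-fold lower number from compound 1 to compound 4 (0.04 log units; within the scatter) that is not taken beyond the scatter. Compound 4 is estimated at 6500 nM, with a range from 2500 nM to 17000 nM.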

Compound 4, half-maximal inhibitory concentration: 3520 nM
For compound 4 the middle estimate is 1.8-fold (0.27 log units) above the measured one; the measured number falls inside the stated range.
By their numbers in this assay, from the lowest: compound 2; then compounds 3 and 4 (each within the scatter of the next); then compound 1.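

In this assay, chloro in place of hydrogen on an aromatic carbon, ortho to a large group and meta to a large group, gives a 2.0-fold lower number from compound 1 to compound 4 (0.31 log units; beyond the scatter). Within the data shown here, the earlier compounds changed only the group on the aromatic nitrogen, so this is the first sign that the read-out also responds to a change on this six-membered aromatic ring, although the step is modest. No supporting measurement bears on why this single chlorine shifts the number.

Fluoro, methyl or methoxy at the same place could show whether the step is particular to chloro or extends to other small groups. From the compounds shown here alone, it also remains open whether this chloro, placed on the core of compound 2 with its neopentyl on the aromatic nitrogen, would add to the step seen with that group.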